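Swapping an Aryl Amine for a Cyclohexyl Amine

A few compounds are considered here, and "the series" means these few. Any claim that something is new, unique, unknown or untested is made for them only; others in the source may bear on it.

Compound 1 `CCOc1ccc(NC2=CC(=O)c3c(nc4n3[C@H]3OC[C@@H](O)[C@H]3OC4)C2=O)cc1`: in a functional assay on MCF7 cells (Homo sapiens) for inhibition, read by sulforhodamine B assay (a higher number here means a weaker inhibitor, a lower number a stronger inhibitor), compound 1 gives only a limit, > 4000 nM.
Compound 2 `O=C1C(NC2CCCC2)=CC(=O)c2c1nc1n2[C@H]2OC[C@@H](O)[C@H]2OC1`: in this assay compound 2 gives only a limit, > 16000 nM.
Compound 3 `CCOc1ccccc1NC1=CC(=O)c2c(nc3n2[C@H]2OC[C@@H](O)[C@H]2OC3)C1=O`: in this assay compound 3 gives only a limit, > 4000 nM.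

Compound 3 stands at a limit in this assay, and the two other measured compounds stand at limits as well, so none of the three can be ranked against another. The three single-change steps among them are accordingly unreadable: a step that the two limits leave unreadable from compound 1 to compound 2, a step that the two limits leave unreadable from compound 1 to compound 3 and a step that the two limits leave unreadable from compound 2 to compound 3 all carry no size.

Compound 4 `O=C1C(NC2CCCCC2)=CC(=O)c2c1nc1n2[C@H]2OC[C@@H](O)[C@H]2OC1` differs from compound 3 in one place: cyclohexyl in place of 2-ethoxyphenyl on an amine nitrogen. The closest guide is compound 2, whose cyclopentyl on the same amine nitrogen sits at the limit of > 16000 nM in this assay, at which 1 of the 3 values shown sits, whereas the two aryl amines, compounds 1 and 3, sit at the limit of > 4000 nM in this assay, at which 2 of the 3 values shown sit. With every step unreadable, no direction can be taken from the data, and a further limit is the most probable outcome.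

Compound 4 is therefore expected to give about 16000 nM in this assay, with a range from 4000 nM to 64000 nM. The step that the limit leaves unreadable from compound 3 to compound 4 that this estimate implies is expected to remain unreadable, with compound 4 reported as a limit rather than a number.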

Compound 4, half-maximal inhibitory concentration: > 16000 nM
Compound 4: a limit, no number (the forecaster's own chance of this, stated with the estimate: 80%); the middle value sits exactly at the limit.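

In this assay compound 4 gives > 16000 nM, a limit and not a number, so its steps from compound 1, compound 2 and compound 3 cannot be read. The compounds shown leave open how cyclohexyl, cyclopentyl, 2-ethoxyphenyl and 4-ethoxyphenyl on the amine nitrogen rank against one another in this assay, and whether any of them gives a measurable value.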